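Carbamoyl for Hydroxy on the Shared Core

The source may hold more compounds than are shown below. What is called first, only, known or untested is meant among the compounds shown, and "the series" means these compounds.

In a physicochemical assay for lipophilicity (a higher number here means a more lipophilic compound, a lower number a more polar compound), compound 1 (`CNc1ccc(-c2nc3ccc(O)cc3s2)cn1`) gives 1.8. Among the compounds with values here, its only measured neighbour, compound 2 (`CN(C)c1ccc(-c2nc3ccc(O)cc3s2)cn1`), gives 2.4, which leaves compound 1 with the lower of the two numbers. Compound 3 (`CNc1ccc(-c2nc3ccc(C(N)=O)cc3s2)cn1`) has not yet been measured. It carries carbamoyl in place of hydroxy on an aromatic carbon. Within the data shown here, the one measured step, a number 0.60 log units higher from compound 1 to compound 2 (beyond the scatter), is a different change, methyl in place of hydrogen on a nitrogen on an aromatic ring. It therefore bears only loosely on this swap, giving a sense of size but no direction. Among the measured compounds shown here, no measured pair tests the swap itself, so a modest downward move is expected, with real uncertainty: the expected step is a number 0.50 log units lower from compound 1 to compound 3 (beyond the scatter). For compound 3 the estimated value is 1.3, with an expected range from 0.8 to 1.9.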

Compound 3, distribution coefficient: 0.5
Compound 3: the middle estimate sits 0.80 log units above what was measured, outside the stated range (below it).
By their numbers in this assay, from the lowest: compound 3; then compound 1; then compound 2.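

At this aromatic carbon, carbamoyl in place of hydroxy gives a number 1.30 log units lower from compound 1 to compound 3 (beyond the scatter) in this assay, a large step that runs the opposite way to the modest one earlier seen at the nitrogen, a number 0.60 log units higher from compound 1 to compound 2 (beyond the scatter), and so shows that this position can move the number strongly downward. The hydrogen-bond donor and acceptor counts are the same for the group that leaves and the group that enters, so those counts do not track the step, though the entering group brings a carbon, a nitrogen and a double bond outside the aromatic rings. No measurement at hand accounts for the size of this step.

As far as these compounds go, whether a carboxylic acid, a methoxy group or an amine at this carbon would give a similar step remains open. Also open, from the compounds shown here alone, is whether carbamoyl in place of hydroxy gives a step of similar size on compound 2.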